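The source may hold more compounds than are shown below. What is called first, only, known or untested is meant among the compounds shown, and "the series" means these compounds.

Compound 2 `CSc1ccc(C2=NN(C(=S)Nc3ccccc3)C(c3ccc4c(c3)OCCO4)C2)cc1` gives 159000 nM in a functional assay on A-375 cells (Homo sapiens) for antiproliferative activity, read by MTT assay, with a stated time of 48 h (on this read-out higher numbers stand for weaker inhibition of growth and lower numbers for stronger inhibition of growth), the higher of the two numbers in hand. Compound 1 `S=C(Nc1ccccc1)N1N=C(c2ccc(Br)cc2)CC1c1ccc2c(c1)OCCO2` gives 470 nM in this assay, and the change a 340-fold higher number from compound 1 to compound 2 (2.53 log units; beyond the scatter) shows that the group at this position moves the number strongly. Compound 3 `S=C(Nc1ccccc1)N1N=C(c2ccc(OCc3ccccc3)cc2)CC1c1ccc2c(c1)OCCO2` differs from compound 2 by benzyloxy in place of methylsulfanyl on an aromatic carbon. For the measured compounds named here, no measured step swaps methylsulfanyl for benzyloxy, so only that one large step bears on the case, and it sets the direction only loosely. Compound 3 is therefore expected to give about 20000 nM in this assay, between 2000 nM and 150000 nM. This estimate means a step of an 8.0-fold lower number from compound 2 to compound 3 (0.90 log units; beyond the scatter) toward stronger inhibition.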

Compound 3, concentration for 50% growth inhibition: 350 nM
Beside the measured number, compound 3's estimate is 57-fold (1.76 log units) above it; the measured number lies below the stated range.
By their numbers in this assay, from the lowest: compounds 3 and 1 (each within the scatter of the next); then compound 2.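

Benzyloxy in place of methylsulfanyl on this aromatic carbon restores strong growth inhibition (a 450-fold lower number from compound 2 to compound 3 (2.66 log units; beyond the scatter)), so the weak number of compound 2 does not extend to every replacement of bromo at this position. Benzyloxy, with its 8 heavy atoms and six-membered aromatic ring, and bromo cannot be told apart here (a 1.3-fold lower number from compound 1 to compound 3 (0.13 log units; within the scatter)), so this position accepts either group. No measurement available here explains why methylsulfanyl stands apart from these two groups. The compounds shown leave open how an amine, a carboxylic acid or a methoxy group would read at this position.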